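A few compounds are considered here, and "the series" means these few. Any claim that something is new, unique, unknown or untested is made for them only; others in the source may bear on it.

Among the measured compounds shown here, compound 2 `Cc1cc(C)n2nc(SCc3nnc(SCc4coc5ccccc5c4=O)n3N)nc2n1` is the only member of the series with a numerical reading in a functional assay on SW480 cells (Homo sapiens) for cytotoxicity, read by MTT assay, with a stated time of 72 h; a higher number here means a weaker inhibitor, a lower number a stronger inhibitor: compound 2 gives 3600 nM. Compound 1 `Cc1cc(C)n2nc(SCc3nnc(SCc4cc(=O)c5ccccc5o4)o3)nc2n1` sits at a limit of this assay rather than at a number, recorded as > 25000 nM. The series therefore rests on a single number and on (the limit of > 25000 nM in this assay, at which 1 of the 2 values shown sits). Compound 3 `Cc1cc(C)n2nc(SCc3nnc(SCc4coc5ccccc5c4=O)n3-c3ccccc3)nc2n1` is the next analogue; it differs from compound 2 by phenyl in place of amino on an aromatic nitrogen. For the measured compounds named here, no measured pair shows a comparable change, so the direction is open. The step of a 1.4-fold higher number from compound 2 to compound 3 (0.14 log units; within the scatter) is expected to be modest, toward weaker inhibition. For compound 3 the estimate in this assay is 5000 nM, within a range of 1500 nM to 20000 nM.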

Compound 3, half-maximal inhibitory concentration: 12400 nM
For compound 3 the middle estimate is 2.5-fold (0.39 log units) below the measured one; low and high end bracket the measured number.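

Phenyl in place of amino on the aromatic nitrogen gives a 3.4-fold higher number from compound 2 to compound 3 (0.54 log units; beyond the scatter) in this assay, so this position affects the reading, toward weaker inhibition. Compound 3 still gives a number rather than a limit, so phenyl at this nitrogen does not remove the numerical reading. Nothing measured here accounts for the size of this step.

A single pair cannot separate the loss of amino from the gain of phenyl. As far as these compounds go, how a methyl group, a benzyl group or a plain hydrogen on this nitrogen would read remains open.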